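The source may report more compounds than this note shows. Statements on the series, on what has been measured and on what is new or still open speak of the compounds shown alone.

Measured so far:
- compound 1 `CCc1ccccc1NS(=O)(=O)c1ccc(N2CCNC2=O)cc1`: 180 nM
- compound 2 `CCCCc1ccc(NS(=O)(=O)c2ccc(N3CCNC3=O)cc2)cc1`: 450 nM

Two compounds of the series have numbers in a functional assay on M21 cells (Homo sapiens) for antiproliferative activity, read by sulforhodamine B assay, with a stated time of 48 h; on this read-out higher numbers stand for weaker inhibition and lower numbers for stronger inhibition. Compound 1 gives 180 nM in this assay. Compound 2 gives 450 nM in this assay, the higher of the two numbers; the gap between compound 2 and compound 1 lies beyond the usual scatter, so compound 2 is the weaker inhibitor of the two measured. The two compounds are not a single-point pair, so nothing more is read from the gap.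

Compound 3 `CCCCOc1ccc(NS(=O)(=O)c2ccc(N3CCNC3=O)cc2)cc1` has not yet been measured. Compared with compound 2, it carries butoxy in place of butyl on an aromatic carbon. Going by the values given here, no measured pair shows this change, so there is no step from which its size can be taken. The expectation for the step from compound 2 to compound 3 is a 1.1-fold lower number from compound 2 to compound 3 (0.05 log units; within the scatter), that is, no shift beyond the scatter in either direction, with the wider range covering the chance that the added acceptor matters either way. Compound 3 is therefore estimated at 400 nM in this assay, with a range from 150 nM to 1200 nM.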

Compound 3, half-maximal inhibitory concentration: 580 nM
The estimate for compound 3 lay 1.5-fold (0.16 log units) below the measured number; low and high end bracket the measured number.
By their numbers in this assay, from the lowest: compound 1; then compounds 2 and 3 (each within the scatter of the next).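

In this assay, the series now has its first single-change step, butoxy in place of butyl on an aromatic carbon para to a large group: a 1.3-fold higher number from compound 2 to compound 3 (0.11 log units; within the scatter). The entering group brings one more heavy atom, an oxygen, and one hydrogen-bond acceptor, and this exchange at this position comes with no shift beyond the scatter, so compound 2 and compound 3 cannot be told apart on this read-out. No measurement on hand bears on why the two compounds read alike, and no reason for it can be given from these data.

This single step does not show whether the tolerance extends to groups of another kind at the same place, such as an amine, a carboxylic acid or a longer alkoxy chain, or whether it holds only for the butyl and butoxy pair. As far as these compounds go, compound 1 differs from compound 2 and compound 3 in more than one place, so the series gives no single-change reading of how its number relates to theirs, and the effect of moving or shortening the chain stays open.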